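Carbamate in place of cyclopropyl amide: stability outlook

The source may report more compounds than this note shows. Statements on the series, on what has been measured and on what is new or still open speak of the compounds shown alone.

Three compounds share one core and differ only at one carbonyl carbon: compound 1 `CCC(=O)N1C[C@@H]2C[C@H]1CN2C(=O)[C@@]1(C(C)C)CC[C@@H](NC2CCOCC2)C1`, compound 2 `CC(C)C(=O)N1C[C@@H]2C[C@H]1CN2C(=O)[C@@]1(C(C)C)CC[C@@H](NC2CCOCC2)C1` and compound 3 `CC(C)[C@]1(C(=O)N2C[C@@H]3C[C@H]2CN3C(=O)C2CC2)CC[C@@H](NC2CCOCC2)C1`. In an in vitro ADME assay on microsomes from liver (Homo sapiens) for metabolic stability, tested at 1 uM (a lower number here means that the compound disappears faster, a higher number that the compound lasts longer), compound 1 gives > 2 h, a limit of the assay rather than a number. Compound 2 gives > 2 h, again a limit. Compound 3 likewise gives > 2 h, also a limit. Because (the limit of > 2 h in this assay, at which 3 of the 3 values shown sit), the steps a step that the two limits leave unreadable from compound 1 to compound 2, a step that the two limits leave unreadable from compound 1 to compound 3 and a step that the two limits leave unreadable from compound 2 to compound 3 cannot be read in size; every measured compound outlasts the longest time the assay follows.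

Compound 4 `CC(OC(=O)N1C[C@@H]2C[C@H]1CN2C(=O)[C@@]1(C(C)C)CC[C@@H](NC2CCOCC2)C1)C(F)(F)F` is not yet measured. Compared with compound 3 the change is 1-(trifluoromethyl)ethoxy in place of cyclopropyl on a carbonyl carbon. Among the measured compounds shown here, none of the measured steps gives a readable size, so the only guide is that all three measured compounds sit at the limit. Compound 4 is therefore expected to land near that same limit, estimated at 2.2 h, with a range from 0.8 h to 4.5 h. The step this estimate implies, a step that the limit leaves unreadable from compound 3 to compound 4, is expected to be small.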

Compound 4, half-life: 1.3 h
Compound 4: the middle estimate sits 1.7-fold (0.23 log units) above what was measured; the range from low to high includes it.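

In this assay, compound 4 is the only compound shown that gives a number rather than a limit, so a change on this carbonyl carbon can bring the half-life off that limit. Replacing cyclopropyl with 1-(trifluoromethyl)ethoxy gives an at least 1.5-fold lower number from compound 3 to compound 4 (0.18 log units; that floor lies within the scatter), while the same group gives an at least 1.5-fold lower number from compound 2 to compound 4 (0.18 log units; that floor lies within the scatter) in place of isopropyl and an at least 1.5-fold lower number from compound 1 to compound 4 (0.18 log units; that floor lies within the scatter) in place of ethyl. Each of these is only a floor within the scatter, so a real loss is not established, and the steps among the first three compounds cannot be read at all, because those values are limits: the limit of > 2 h in this assay, at which 3 of the 4 values shown sit.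

As far as these compounds go, what stays open is whether the lower reading belongs to the oxygen link on the carbonyl carbon or to the trifluoromethyl group. A plain ethoxy group or a dimethylamino group at this place would help to separate the two.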